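Trifluoromethylphenyl for cyanophenyl on the second amine core

A few compounds are considered here, and "the series" means these few. Any claim that something is new, unique, unknown or untested is made for them only; others in the source may bear on it.

Compound 1 `COc1ccc(F)cc1CNCCCNc1ccnc2cc(Cc3ccc(C#N)cc3)ccc12` is the starting point of the set. In an ADME assay on HepG2 cells (Homo sapiens) for cytotoxicity, read by luminescence, CellTiter-Glo and ATP content, with a stated time of 72 h (on this read-out higher numbers stand for an effect only at larger amounts of compound and lower numbers for an effect already at smaller amounts), compound 1 gives 6050 nM. Compound 2 `COc1ccc(F)cc1CNCCCNc1ccnc2cc(Cc3cccc(C(F)(F)F)c3)ccc12` carries the change 3-(trifluoromethyl)phenyl in place of 4-cyanophenyl on a saturated chain carbon bound to an aromatic carbon and in this assay compound 2 gives 440 nM; the step is a 14-fold lower number from compound 1 to compound 2 (1.14 log units; beyond the scatter). Compound 3 `N#Cc1ccc(Cc2ccc3c(NCCCNCc4ccco4)ccnc3c2)cc1` keeps the 4-cyanophenyl arm and in this assay compound 3 gives 7910 nM; the step is a 1.3-fold higher number from compound 1 to compound 3 (0.12 log units; within the scatter), so the two cores behave alike on this read-out.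

Compound 4 `FC(F)(F)c1cccc(Cc2ccc3c(NCCCNCc4ccco4)ccnc3c2)c1` has not been measured. It differs from compound 3 by 3-(trifluoromethyl)phenyl in place of 4-cyanophenyl on a saturated chain carbon bound to an aromatic carbon. This is the same change that turns compound 1 into compound 2, and it occurs twice among the compounds here, at the same place in both pairs. The cores of the two pairs differ by furan-2-yl in place of 5-fluoro-2-methoxyphenyl on a saturated chain carbon bound to an amine nitrogen.

Going by the values given here, only one measured step carries this change, so the expectation rests on it alone. The step from compound 3 to compound 4 is expected to be a 13-fold lower number from compound 3 to compound 4 (1.12 log units; beyond the scatter), set beside a 14-fold lower number from compound 1 to compound 2 (1.14 log units; beyond the scatter), with wider bounds because a single pair cannot show how well the step transfers. Compound 4 is thus estimated at 600 nM in this assay, expected to fall between 250 nM and 1500 nM.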

Compound 4, half-maximal effective concentration: 3190 nM
For compound 4 the middle estimate is 5.3-fold (0.73 log units) below the measured one, outside the stated range (above it).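

In this assay the change to 3-(trifluoromethyl)phenyl on the furan-2-yl core gives a 2.5-fold lower number from compound 3 to compound 4 (0.39 log units; beyond the scatter) and so keeps the direction seen on the core of compound 1, but the size of the step does not carry over: the same change on two cores in this assay, a 14-fold lower number (1.14 log units; beyond the scatter) from compound 1 to compound 2 and a 2.5-fold lower number (0.39 log units; beyond the scatter) from compound 3 to compound 4, 5.5-fold (0.74 log units) apart, beyond the scatter of two such steps.

Read the other way, furan-2-yl in place of 5-fluoro-2-methoxyphenyl gives a 7.3-fold higher number from compound 2 to compound 4 (0.86 log units; beyond the scatter) with the 3-(trifluoromethyl)phenyl arm, whereas with the 4-cyanophenyl arm the step stays within the scatter: the same change on two cores in this assay, a 1.3-fold higher number (0.12 log units; within the scatter) from compound 1 to compound 3 and a 7.3-fold higher number (0.86 log units; beyond the scatter) from compound 2 to compound 4, 5.5-fold (0.74 log units) apart, beyond the scatter of two such steps.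

The two changes therefore do not add up independently on this read-out, so a step taken from one core is a guide to direction at best; two pairs do not show why the size differs, nor which of the two steps a further core would follow.

On these data alone, it remains open whether this dependence extends to other groups on these two sites. A chlorophenyl group on the saturated chain carbon, or a thiophene in place of furan-2-yl, would test that.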